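Bis(trifluoromethyl)benzenesulfonamide diamines against PANC-1 growth

The source may hold more compounds than are shown below. What is called first, only, known or untested is meant among the compounds shown, and "the series" means these compounds.

Measured so far:
compound 1, `CC(C)(C)c1ccc(CNCCNS(=O)(=O)c2cc(C(F)(F)F)cc(C(F)(F)F)c2)cc1`: 13000 nM
compound 2, `O=S(=O)(NCCCCNCc1ccc(Br)cc1)c1cc(C(F)(F)F)cc(C(F)(F)F)c1`: 2200 nM

In a functional assay on PANC-1 cells (Homo sapiens) for inhibition, read by MTT assay, with a stated time of 72 h (on this read-out lower numbers stand for stronger inhibition of growth and higher numbers for weaker inhibition of growth), compound 2 gives the lower of the two numbers; compound 1 sits at 13000 nM, a gap beyond the scatter. Compound 3, `O=S(=O)(NCCCNCc1ccccc1Cl)c1cc(C(F)(F)F)cc(C(F)(F)F)c1`, is not yet measured. It differs from compound 2 by (2-chlorobenzyl)amino in place of ((4-bromobenzyl)amino)methyl on a saturated chain carbon, three bonds along the chain from a sulfonamide nitrogen. Going by the values given here, no measured pair isolates this change, so the step is uncertain. A modest move toward a higher number is expected, possibly within the scatter. Compound 3 is estimated at 4000 nM, range 1500 nM to 12000 nM. The estimated step is a 1.8-fold higher number from compound 2 to compound 3 (0.26 log units; within the scatter) in this assay.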

Compound 3, concentration for 50% growth inhibition: 15000 nM
Estimate against measurement, compound 3: 3.8-fold (0.57 log units) below; measured number outside the range, above it.
By their numbers in this assay, from the lowest: compound 2; then compounds 1 and 3 (each within the scatter of the next).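

In this assay, (2-chlorobenzyl)amino in place of ((4-bromobenzyl)amino)methyl on a saturated chain carbon, three bonds along the chain from a sulfonamide nitrogen, gives a 6.8-fold higher number from compound 2 to compound 3 (0.83 log units; beyond the scatter). Going by these compounds alone, this is the first comparison that differs in one place, and it shows that growth inhibition responds to a change at this position. No available measurement accounts for the size of this step. As far as these compounds go, the change alters the chain and the halogen-bearing benzyl group together, so their separate contributions remain open. A (4-bromobenzyl)amino group at this place would separate them.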